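Sec-butyl in place of isopropyl on compound 2

The compounds below may be only part of what the source reports. "The series", "measured", "known", "first", "only" and "open" are said of these compounds alone.

Values so far in an ADME assay on MT4 cells (Homo sapiens) for activation, read by MTT assay; on this read-out lower numbers stand for higher toxicity in this test and higher numbers for lower toxicity in this test:
- compound 1 `CCC(C)Sc1nc(C(C)c2c(F)cccc2Cl)cc(=O)[nH]1`: > 73000 nM (a limit)
- compound 2 `CCc1c(C(C)c2c(F)cccc2Cl)nc(SC(C)C)[nH]c1=O`: > 3000 nM (a limit)

Compound 2 stands only at a limit in this assay, reading > 3000 nM with no number behind it. Compound 1 is also known only as a limit, reading > 73000 nM in the same test. For the measured compounds named here, the two entries therefore cannot be placed in order, and the series offers no measured step between compounds to size a change.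

The next compound is compound 3 `CCc1c(C(C)c2c(F)cccc2Cl)nc(SC(C)CC)[nH]c1=O`, which differs from compound 2 by methyl in place of hydrogen on a saturated chain carbon, two bonds along the chain from a sulfur. In words, isopropylsulfanyl becomes (sec-butyl)sulfanyl.

In this assay, the expected step, a step that the limit leaves unreadable from compound 2 to compound 3, is none beyond the usual scatter, and no firm direction is expected. This expectation rests on the single added methyl and on compound 2 at > 3000 nM, which is a limit. Another limit is also a likely report for the new compound. The estimated value for compound 3 is 5000 nM, with an expected range from 1500 nM to 40000 nM.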

Compound 3, half-maximal cytotoxic concentration: > 3000 nM
Compound 3: no number, only a limit; the forecaster's own chance of this, stated with the estimate: 70%; the middle value is on the limit's open side.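

No step can be read among compound 1, compound 2 and compound 3 in this assay: all three stand only as limits. The compounds shown leave open at what concentration any of them reaches half-maximal cytotoxicity, and whether methyl in place of hydrogen on a saturated chain carbon, two bonds along the chain from a sulfur, shifts that concentration at all.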